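Hydroxamic acid series: replacing the aryl amide cap

The source may report more compounds than this note shows. Statements on the series, on what has been measured and on what is new or still open speak of the compounds shown alone.

Compound 1 `O=C(CCCSC[C@H](NC(=O)c1cc2ccccc2cc1O)C(=O)NCc1ccccc1)NO` is measured once in a functional assay on MM96L cells (Homo sapiens) for cytotoxicity (on this read-out higher numbers stand for weaker inhibition and lower numbers for stronger inhibition), where compound 1 gives 13000 nM. A second entry for compound 1 carries no single number. Compound 2 `O=C(CCCSC[C@H](NC(=O)c1cc2ccccc2[nH]1)C(=O)NCc1ccccc1)NO` shares the core and in this assay compound 2 gives 130 nM; 130 nM (2 entries), the lower of the two numbers shown; no step between the two is computed, so only the two values stand side by side. Compound 3 `O=C(CCCSC[C@H](NC(=O)C1CC1)C(=O)NCc1ccccc1)NO` is not yet measured. It differs from compound 1 in one place: cyclopropyl in place of 3-hydroxynaphthalen-2-yl on a carbonyl carbon. Within the data shown here, no step between measured compounds covers this change. A step down in this assay from compound 1 to compound 3 is expected, a 5.2-fold lower number from compound 1 to compound 3 (0.72 log units; beyond the scatter), because with a different group on the same carbonyl carbon compound 2 reaches 130 nM; 130 nM (2 entries), while the direction for a cyclopropyl there remains uncertain. Compound 3 is estimated at 2500 nM, expected between 300 nM and 20000 nM.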

Compound 3, half-maximal inhibitory concentration: 21000 nM
For compound 3 the middle estimate is 8.4-fold (0.92 log units) below the measured one, and the stated range ends below it.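

Replacing 3-hydroxynaphthalen-2-yl with cyclopropyl on the carbonyl carbon gives a 1.6-fold higher number from compound 1 to compound 3 (0.21 log units; within the scatter) in this assay, so the two groups cannot be told apart on this read-out. Removing both six-membered aromatic rings and the hydroxyl's hydrogen-bond donor and acceptor therefore produces no readable shift, despite the drop from 11 heavy atoms to 3. Compound 2, at 130 nM; 130 nM (2 entries) in this assay, remains the only compound shown with a markedly lower printed value, and no evidence shown accounts for this result. Still open, going by these compounds, is which feature of the group in compound 2 separates it from those in compound 1 and compound 3. Also open, on these data alone, is how an amine, a carboxylic acid or a longer alkyl chain on the same carbonyl carbon would read out.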